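Reversing the Amide and Trading Phenyl for Oxolane

The compounds below may be only part of what the source reports. "The series", "measured", "known", "first", "only" and "open" are said of these compounds alone.

Of the compounds shown here, three built on one shared core have been measured in an assay on CHO-K1 cells for displacement of a labelled ligand from prostaglandin E2 receptor EP1 subtype (Homo sapiens); on this read-out higher numbers stand for weaker inhibition and lower numbers for stronger inhibition. Compound 1 `Cc1cc(C(N)=O)nn1Cc1cc(Cl)ccc1OCc1ccccc1` gives 126 nM. Compound 2 `Cc1cc(C(=O)Nc2ccccc2)nn1Cc1cc(Cl)ccc1OCc1ccccc1` gives 39.8 nM, and compound 3 `Cc1cc(C(=O)NCc2cccnc2)nn1Cc1cc(Cl)ccc1OCc1ccccc1` gives 50.1 nM. Within the data shown here, compound 2 thus stands at the lowest of the three numbers, but the gap a 1.3-fold higher number from compound 2 to compound 3 (0.10 log units; within the scatter) is within the scatter, so compounds 2 and 3 cannot be told apart; only the step of a 3.2-fold lower number from compound 1 to compound 2 (0.50 log units; beyond the scatter) lies beyond it.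

Compound 4 `Cc1cc(NC(=O)C2CCCO2)nn1Cc1cc(Cl)ccc1OCc1ccccc1` has not yet been measured. Relative to compound 2 the change is ((oxolan-2-yl)carbonyl)amino in place of phenylcarbamoyl on an aromatic carbon. Among the measured compounds shown here, no measured step reverses the amide or replaces an aromatic ring on the amide nitrogen with a non-aromatic one, so the known steps bear on this change only indirectly. The steps of a 3.2-fold lower number from compound 1 to compound 2 (0.50 log units; beyond the scatter) and a 2.5-fold lower number from compound 1 to compound 3 (0.40 log units; beyond the scatter) show that a group on the amide nitrogen lowers the number modestly compared with hydrogen, and compound 4 no longer carries the phenyl that compound 2 has there. The expected outcome for compound 4 is therefore a modest move back toward the number of compound 1, estimated as a 3.8-fold higher number from compound 2 to compound 4 (0.58 log units; beyond the scatter). Compound 4 is expected to give 150 nM in this assay, with a range from 40 nM to 600 nM.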

Compound 4, half-maximal inhibitory concentration: 39.8 nM
The estimate for compound 4 lay 3.8-fold (0.58 log units) above the measured number, outside the stated range (below it).
By their numbers in this assay, from the lowest: compounds 2, 4 and 3 (each within the scatter of the next); then compound 1.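

In this assay the exchange of phenylcarbamoyl for ((oxolan-2-yl)carbonyl)amino on this aromatic carbon gives no change at the digits printed from compound 2 to compound 4 (within the scatter) and the comparison with the pyridine-bearing amide gives a 1.3-fold lower number from compound 3 to compound 4 (0.10 log units; within the scatter), so these three compounds cannot be told apart, even though the amide is reversed and a five-membered non-aromatic ring with 1 hetero atom stands where an aromatic ring stood. The plain carbamoyl compound remains separated, with a 3.2-fold lower number from compound 1 to compound 4 (0.50 log units; beyond the scatter) of the same modest size as the step to the phenyl amide, so among the compounds shown neither the original amide direction nor an aromatic ring on the amide is needed to reach this level. The data offer no evidence on why the two different amides give matching numbers.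

Because compound 4 changes the amide direction and the ring together, the compounds shown do not separate the contribution of each change. From the compounds shown here alone, it also remains open whether a longer alkyl chain, an amine or a carboxylic acid in place of the oxolane ring would keep the number at this level.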